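Swapping the aryl group on the chain of compound 3

This account rests on a few compounds, and the source may have more. Where it says the series, first, only, none or still open, it means among the compounds named here.

Three compounds share one core and differ only in the aryl group on a double-bonded chain carbon. In a functional assay on DU-145 cells (Homo sapiens) for inhibition, read by trypan blue exclusion, with a stated time of 96 h (on this read-out higher numbers stand for weaker inhibition of growth and lower numbers for stronger inhibition of growth), compound 1 `COc1ccccc1/C=C(/SCc1ccc(C)cc1)C(=O)c1ccc(Cl)cc1` gives 10000 nM, compound 2 `Cc1ccc(CS/C(=C/c2cc(Cl)cc(Cl)c2)C(=O)c2ccc(Cl)cc2)cc1` gives 10000 nM, and compound 3 `Cc1ccc(CS/C(=C/c2sccc2C)C(=O)c2ccc(Cl)cc2)cc1` gives 10000 nM. Compound 3 thus stands level with both neighbours: no change at the digits printed from compound 1 to compound 3 (within the scatter) and no change at the digits printed from compound 2 to compound 3 (within the scatter), just as no change at the digits printed from compound 1 to compound 2 (within the scatter). Compound 4 `Cc1ccc(CS/C(=C/c2ccccc2Br)C(=O)c2ccc(Cl)cc2)cc1` changes the same position once more: 2-bromophenyl in place of 3-methylthiophen-2-yl on a double-bonded chain carbon bound to a double-bonded chain carbon. Every measured swap at this position left the read-out unchanged, so no shift beyond the scatter is expected for this assay, and the step of no change at the digits printed from compound 3 to compound 4 (within the scatter) is an estimate of that. Compound 4 is therefore expected to give about 10000 nM in this assay, within 5000 nM to 20000 nM.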

Compound 4, concentration for 50% growth inhibition: 10000 nM
Compound 4: middle estimate and measured number agree at the digits printed, and the stated range covers the measured number.
By their numbers in this assay, from the lowest: compounds 1, 2, 3 and 4 (each within the scatter of the next).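

In this assay, the 2-bromophenyl group matches the other aryl groups tested at this place: no change at the digits printed from compound 3 to compound 4 (within the scatter), no change at the digits printed from compound 2 to compound 4 (within the scatter) and no change at the digits printed from compound 1 to compound 4 (within the scatter). The last step is the smallest change so far, bromo in place of methoxy on an aromatic carbon, and even this leaves the read-out as it was. No supporting measurements are available to explain this flat result. The compounds shown leave open whether a phenyl ring carrying an amine or a carboxylic acid at this place would shift the number, and whether changes elsewhere on the shared core would.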